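The compounds below may be only part of what the source reports. "The series", "measured", "known", "first", "only" and "open" are said of these compounds alone.

Measured so far:
compound 1 `Cc1ccccc1Nc1nc(NC2CCCCC2)ncc1Cl` — > 100000 nM (a limit, not a number)
compound 2 `Cc1ccccc1Nc1nc(Nc2ccc(N3CCNCC3)cn2)ncc1Cl` — 1850 nM
compound 3 `CN1CCN(c2ccc(Nc3ncc(Cl)c(NCc4ccccc4)n3)nc2)CC1` — 20300 nM

In an ADME assay on L02 cells (Homo sapiens) for inhibition, read by CCK-8 assay, with a stated time of 48 h (on this read-out higher numbers stand for weaker inhibition of growth and lower numbers for stronger inhibition of growth), compound 1 sits at the limit of > 100000 nM in this assay, at which 1 of the 3 values shown sits. Of the two compounds with a number, compound 3 stands highest, at 20300 nM. Compound 2 gives 1850 nM, a lower number, and the gap between the two lies beyond the scatter.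

Compound 4 `Cc1cccc(Nc2nc(Nc3ccc(N4CCN(C)CC4)cn3)ncc2Cl)c1` differs from compound 3 in one place: 3-methylphenyl in place of benzyl on a nitrogen on an aromatic ring. The piperazine end is unchanged, so the comparison with compound 3 is clean, and compound 2 also carries an arylamino group at that nitrogen with its value of 1850 nM.

Among the compounds with values here, no measured pair isolates this change. In this assay the step from compound 3 to compound 4 is expected to run downward and to exceed the scatter, estimated at a 5.8-fold lower number from compound 3 to compound 4 (0.76 log units; beyond the scatter). Compound 4 is accordingly expected at 3500 nM, with the likely range 1200 nM to 12000 nM.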

Compound 4, concentration for 50% growth inhibition: 6080 nM
Beside the measured number, compound 4's estimate is 1.7-fold (0.24 log units) below it; low and high end bracket the measured number.
By their numbers in this assay, from the lowest: compound 2; then compound 4; then compound 3. At a limit, above all of these: compound 1.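

In this assay, within the data shown here, the change to 3-methylphenyl in place of benzyl on a nitrogen on an aromatic ring gives a 3.3-fold lower number from compound 3 to compound 4 (0.52 log units; beyond the scatter) and this is the first step read at this place with the rest of the molecule unchanged. The two compounds hold the same atoms joined differently, so a step beyond the scatter appears here with no change in composition. Nothing among the data at hand bears on what lies behind this step.

On these data alone, whether the step keeps its direction with other groups on this nitrogen, such as plain phenyl or a longer chain like 2-phenylethyl, remains open. Also open, as far as these compounds go, is whether it carries over to the unsubstituted piperazine end of compound 2.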